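Removing One Methoxy From a Shared Quinoxaline-Free Core

A few compounds are considered here, and "the series" means these few. Any claim that something is new, unique, unknown or untested is made for them only; others in the source may bear on it.

Three close relatives share one core, and each was tested in a functional assay on HOP-62 cells (Homo sapiens) for inhibition, read by sulforhodamine B assay, with a stated time of 48 h; a lower number here means that less compound is tolerated, a higher number that more compound is tolerated. Compound 1 `CCOC(=O)[C@H](CCC(=O)O)NC(=O)c1ccc(CNc2nc3cc(N)cc(N)c3nc2-c2ccccc2)cc1` gives only a limit, < 100000 nM. Among the compounds with values here, compound 2 `COc1ccc(CNc2nc3cc(N)cc(N)c3nc2-c2ccccc2)cc1OC` gives the one plain number, 64600 nM. Compound 3 `COc1cc(CNc2nc3cc(N)cc(N)c3nc2-c2ccccc2)cc(OC)c1OC` likewise gives only a limit, < 50200 nM. Within the data shown here, the single step between measured neighbours, an at least 1.2-fold lower number from compound 2 to compound 3 (0.10 log units; that floor lies within the scatter), rests on that limit of < 50200 nM in this assay, at which 1 of the 3 values shown sits, and stays within the scatter.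

Compound 4 `COc1ccc(CNc2nc3cc(N)cc(N)c3nc2-c2ccccc2)cc1` is not yet measured. It differs from compound 2 by hydrogen in place of methoxy on an aromatic carbon, which is to say a hydrogen in place of methoxy on an aromatic carbon. Among the measured compounds shown here, the only measured step, from compound 2 to compound 3, went the other way, adding a methoxy, and produced no change beyond the scatter; so taking one away is expected to produce none either. For compound 4 the expected outcome in this assay is 70000 nM, with a range from 30000 nM to 160000 nM, meaning an expected step of a 1.1-fold higher number from compound 2 to compound 4 (0.03 log units; within the scatter).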

Compound 4, concentration lethal to 50% of the cells: 69200 nM
Estimate against measurement, compound 4: 1.0-fold (0.00 log units) above; low and high end bracket the measured number.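

In this assay, the step of a 1.1-fold higher number from compound 2 to compound 4 (0.03 log units; within the scatter) is the only one shown that is read between two plain numbers rather than against a limit. It shows that the 3,4-dimethoxyphenyl of compound 2 and the 4-methoxyphenyl of compound 4 cannot be told apart here, so hydrogen can stand in place of the methoxy ortho to a methoxy group with both numbers staying within the scatter. Nothing shown gives a measured reason for this result.

The compounds shown leave open whether another group at this place, such as an amine or a carboxylic acid, would give a number beyond the scatter. They also leave open what happens when the remaining methoxy of compound 4 is replaced by hydrogen.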